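Methoxy to trifluoromethoxy, once measured and once to be measured

This account rests on a few compounds, and the source may have more. Where it says the series, first, only, none or still open, it means among the compounds named here.

Measured compounds, in a functional assay on P388 cells (Mus musculus) for inhibition; a higher number here means a weaker inhibitor, a lower number a stronger inhibitor:
compound 1 `COc1ccc(/C=C/c2ccc3ccccc3c2)cc1`, a limit of the assay: > 5000 nM
compound 2 `COc1cccc(/C=C\c2ccc3ccccc3c2)c1`: 1920 nM
compound 3 `FC(F)(F)Oc1ccc(/C=C/c2ccc3ccccc3c2)cc1`, a limit of the assay: > 5000 nM

The change from compound 1 to compound 3 is trifluoromethyl in place of methyl on an oxygen on an aromatic ring. Its size is a step that the two limits leave unreadable from compound 1 to compound 3, and this is so because of the limit of > 5000 nM in this assay, at which 2 of the 3 values shown sit. Compound 2 shares its atoms with compound 1 but joined differently; the difference between the two cores is not broken down here. Compound 4 `FC(F)(F)Oc1cccc(/C=C\c2ccc3ccccc3c2)c1` is not yet measured in this assay. It differs from compound 2 by trifluoromethyl in place of methyl on an oxygen on an aromatic ring, the same kind of change as from compound 1 to compound 3, in the same place. With the earlier step unreadable, the expectation for compound 4 rests only on compound 2 at 1920 nM and is wide: an estimated step of a 1.8-fold higher number from compound 2 to compound 4 (0.26 log units; within the scatter). Compound 4 is expected at 3500 nM, estimated between 1200 nM and 10000 nM.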

Compound 4, half-maximal inhibitory concentration: 3500 nM
The estimate for compound 4 equals the measured number at the digits printed, within the range that was stated.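

In this assay, trifluoromethyl in place of methyl on the oxygen gives a 1.8-fold higher number from compound 2 to compound 4 (0.26 log units; within the scatter), so on the core of compound 2 the two groups cannot be told apart. On the core of compound 1 the same change cannot be read, because both of its compounds stand at a limit rather than a number: the limit of > 5000 nM in this assay, at which 2 of the 4 values shown sit. The series therefore holds one readable instance of this change, which neither shows that the step carries from one core to the other nor shows that it does not.

Open, on these data alone, is whether an amine or a longer chain such as ethoxy in place of methoxy would give a step beyond the scatter on the core of compound 2. Also open, as far as these compounds go, is whether any group gives a readable number on the core of compound 1.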